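Replacing 3-fluorophenyl with naphthalen-1-yl on the sulfonyl sulfur

A few compounds are considered here, and "the series" means these few. Any claim that something is new, unique, unknown or untested is made for them only; others in the source may bear on it.

Compound 1 `O=S(=O)(NCCCNc1nccc(-c2[nH]c(-c3ccccc3)nc2-c2ccc(Cl)c(O)c2)n1)c1ccccc1`: 2630 nM
Compound 2 `O=S(=O)(NCCCNc1nccc(-c2[nH]c(-c3ccccc3)nc2-c2ccc(Cl)c(O)c2)n1)c1cccc(F)c1`: 33600 nM

In a functional assay on LOX IMVI cells (Homo sapiens) for cytotoxicity, read by MTT assay, with a stated time of 24 h (on this read-out higher numbers stand for weaker inhibition and lower numbers for stronger inhibition), compound 2 gives the higher of the two numbers, 33600 nM, and sits well above compound 1 at 2630 nM. Compound 3 `O=S(=O)(NCCCNc1nccc(-c2[nH]c(-c3ccccc3)nc2-c2ccc(Cl)c(O)c2)n1)c1cccc2ccccc12`, not yet measured, has naphthalen-1-yl in place of 3-fluorophenyl on a sulfonyl sulfur. Among the compounds with values here, only one measured step bears on this change: a 13-fold higher number from compound 1 to compound 2 (1.11 log units; beyond the scatter), a large step beyond the scatter, for fluoro in place of hydrogen on an aromatic carbon. Within the data shown here, compound 3 carries no fluoro, so a partial return towards compound 1 is expected, although no measured compound shows what the second ring does. The expected change is a 4.2-fold lower number from compound 2 to compound 3 (0.62 log units; beyond the scatter), a moderate move to a lower number in this assay. For compound 3, the estimated value is 8000 nM, with an expected range of 1800 nM to 35000 nM.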

Compound 3, half-maximal inhibitory concentration: 7720 nM
Estimate against measurement, compound 3: 1.0-fold (0.02 log units) above; measured number inside the range.
By their numbers in this assay, from the lowest: compound 1; then compound 3; then compound 2.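

In this assay, naphthalen-1-yl on the sulfonyl sulfur gives a lower number than 3-fluorophenyl (a 4.4-fold lower number from compound 2 to compound 3 (0.64 log units; beyond the scatter)), but a higher number than phenyl (a 2.9-fold higher number from compound 1 to compound 3 (0.47 log units; beyond the scatter)). This position therefore holds two six-membered aromatic rings of carbon without reaching the high number of compound 2, while compound 1, with phenyl, keeps the lowest number of the three. Since compound 3 both lacks the fluoro and adds a ring, its step from compound 2 does not separate the two changes.

The compounds shown leave open how a naphthalen-2-yl, a 3-chlorophenyl or a 3-methoxyphenyl group on the sulfonyl sulfur would compare with these three. Nothing given here explains the sizes of these steps.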